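A few compounds are considered here, and "the series" means these few. Any claim that something is new, unique, unknown or untested is made for them only; others in the source may bear on it.

Measured compounds:
Compound 1 `Cc1cc(Oc2ccccc2OCCn2ccc(=O)[nH]c2=O)cc2cc(C#N)ccc12`: 6000 nM
Compound 2 `Cc1cc(Oc2ccccc2OCCn2ccc(=O)[nH]c2=O)c(C)c2cc(C#N)ccc12`: > 100000 nM

Compound 2 `Cc1cc(Oc2ccccc2OCCn2ccc(=O)[nH]c2=O)c(C)c2cc(C#N)ccc12` is the starting point. In a toxicity assay on MT2 cells (Homo sapiens) for cytotoxicity, read by MTT assay (on this read-out lower numbers stand for higher toxicity in this test and higher numbers for lower toxicity in this test), compound 2 gives > 100000 nM, which is a limit of the assay rather than a measured number, as the limit of > 100000 nM in this assay, at which 1 of the 2 values shown sits, shows. Compound 1 `Cc1cc(Oc2ccccc2OCCn2ccc(=O)[nH]c2=O)cc2cc(C#N)ccc12` differs from compound 2 by a single methyl, and in this assay compound 1 gives 6000 nM. Among the compounds with values here, the only measured step, an at least 16-fold higher number from compound 1 to compound 2 (1.22 log units; beyond the scatter), is beyond the scatter and ends at the limit.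

Compound 3 `CCOc1cc(Oc2ccccc2OCCn2ccc(=O)[nH]c2=O)c(C)c2cc(C#N)ccc12` has not yet been measured. It differs from compound 2 by ethoxy in place of methyl on an aromatic carbon. Within the data shown here, no measured step covers this kind of change, so the only guidance is that compound 2 already sits at the limit while compound 1 stands well below it. For compound 3 the expectation is therefore a value close to the limit, so that a number no higher from compound 2 to compound 3 (the limit leaves the size open) is expected to stay within the scatter, in either direction. Compound 3 is estimated at 100000 nM, between 30000 nM and 300000 nM, with a fair chance that this assay again reports only a limit.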

Compound 3, half-maximal cytotoxic concentration: > 100000 nM
Compound 3: only a limit was reported (the forecaster's own chance of this, stated with the estimate: 60%); the middle value sits exactly at the limit.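

In this assay compound 3 gives > 100000 nM, which is a limit of the assay and not a number. Within the data shown here, no step from compound 2 to compound 3 can be read, because both compounds stop at the same limit: the limit of > 100000 nM in this assay, at which 2 of the 3 values shown sit. The compounds shown leave open whether ethoxy in place of methyl changes the toxicity number at all, and by how much.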